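Variation at the piperazine nitrogen in a Jurkat cell series

The compounds below may be only part of what the source reports. "The series", "measured", "known", "first", "only" and "open" are said of these compounds alone.

The measured compounds:
compound 1, `COC(=O)c1ccc(C2SCC(=O)N2c2ccc(N3CCN(Cc4cccc([N+](=O)[O-])c4)CC3)cn2)c(OC)c1`, 37400 nM
compound 2, `COC(=O)c1ccc(C2SCC(=O)N2c2ccc(N3CCN(Cc4ccc(Cl)c(Cl)c4)CC3)cn2)c(OC)c1`, 61000 nM
compound 3, `COC(=O)c1ccc(C2SCC(=O)N2c2ccc(N3CCN(S(=O)(=O)c4ccccc4)CC3)cn2)c(OC)c1`, 52900 nM

All three were tested in a functional assay on Jurkat cells (Homo sapiens) for antiproliferative activity, read by MTT assay and trypan blue exclusion, with a stated time of 72 h; on this read-out lower numbers stand for stronger inhibition and higher numbers for weaker inhibition. Compound 1 has the lowest of the three numbers, but its neighbours sit close: the step of a 1.4-fold higher number from compound 1 to compound 3 (0.15 log units; within the scatter) and the step of a 1.6-fold higher number from compound 1 to compound 2 (0.21 log units; within the scatter) both stay within the scatter, so no order among them can be claimed. The same holds for a 1.2-fold lower number from compound 2 to compound 3 (0.06 log units; within the scatter).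

The next compound, compound 4, `COC(=O)c1ccc(C2SCC(=O)N2c2ccc(N3CCN(S(=O)(=O)c4c(C)cc(C)cc4C)CC3)cn2)c(OC)c1`, differs from compound 1 by (2,4,6-trimethylphenyl)sulfonyl in place of 3-nitrobenzyl on an amine nitrogen in a ring. Among the compounds with values here, the step that bears most directly on it is the one from compound 1 to compound 3, where a phenylsulfonyl also took the place of the 3-nitrobenzyl on the ring nitrogen and the number barely moved. The other two steps, which also exchange the group on that nitrogen, moved the numbers no further. Three exchanges at this position thus left this assay essentially unchanged, and nothing among them suggests that the added three methyl groups on the aromatic ring would alter that.

Compound 4 is therefore expected to show no step beyond the scatter, a 1.2-fold higher number from compound 1 to compound 4 (0.08 log units; within the scatter), and its estimated value in this assay is 45000 nM, with a range from 15000 nM to 140000 nM.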

Compound 4, half-maximal inhibitory concentration: > 100000 nM
Compound 4 ended at the assay's limit; the forecaster's own chance of this, stated with the estimate: 15%; middle value at least 2.2-fold (0.34 log units) from the limit.
By their numbers in this assay, from the lowest: compounds 1, 3 and 2 (each within the scatter of the next). At a limit, above all of these: compound 4.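

In this assay compound 4 gives > 100000 nM, which is a limit of the assay and not a number. Within the data shown here, the step of an at least 2.6-fold higher number from compound 1 to compound 4 (0.42 log units; beyond the scatter) is the first exchange on the amine nitrogen in a ring that passes beyond the scatter, so this position is not as indifferent to its substituent as compounds 1, 2 and 3 alone suggested. The step of an at least 1.8-fold higher number from compound 3 to compound 4 (0.27 log units; that floor lies within the scatter) and the step of an at least 1.6-fold higher number from compound 2 to compound 4 (0.21 log units; that floor lies within the scatter) each rest on a floor within the scatter, so it remains unsettled whether 2,4,6-trimethylphenyl in place of phenyl on the sulfonyl sulfur changes the number at all, even though the first of these two pairs isolates the change most closely.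

The limit leaves the true size of the step unknown, and the compounds shown do not separate the contribution of the methyl groups from one another, as a phenylsulfonyl carrying only one methyl group might. Also open, going by these compounds, is how the series would respond to a small alkylsulfonyl such as methanesulfonyl, an acetyl group, or a free amine hydrogen on that nitrogen.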